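A Larger Aryl Group on the Ring Nitrogen of Compound 2

A few compounds are considered here, and "the series" means these few. Any claim that something is new, unique, unknown or untested is made for them only; others in the source may bear on it.

Compound 1 `O=C(Nc1ccc(Oc2ccnc3[nH]ccc23)cc1)c1nn(-c2ccc(Br)cc2)ccc1=O`: 8040 nM
Compound 2 `O=C(Nc1ccc(Oc2ccnc3[nH]ccc23)c(F)c1)c1nn(-c2ccc(Br)cc2)ccc1=O`: 40800 nM

Both numbers come from a functional assay on PC-3 cells (Homo sapiens) for cytotoxicity, read by MTT assay, with a stated time of 72 h; on this read-out higher numbers stand for weaker inhibition and lower numbers for stronger inhibition. Among the measured compounds shown here, compound 2 stands highest of the two; its nearest neighbour is compound 1, and the only step measured so far, a 5.1-fold higher number from compound 1 to compound 2 (0.71 log units; beyond the scatter), separates them. That step concerns a fluoro group on one aromatic carbon of the shared core and nothing else.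

Compound 3 `O=C(Nc1ccc(Oc2ccnc3[nH]ccc23)c(F)c1)c1nn(-c2ccc(Cl)c(C(F)(F)F)c2)ccc1=O` keeps that fluoro group and changes a different part: 4-chloro-3-(trifluoromethyl)phenyl in place of 4-bromophenyl on an aromatic nitrogen. For the measured compounds named here, no measured step touches the group on this aromatic nitrogen, so the single step in hand does not bear on the change, and it offers no direction to lean on. In this assay a step from compound 2 to compound 3 of no more than the usual scatter is therefore expected, with wide room either way. The estimate for compound 3 is 30000 nM, between 8000 nM and 120000 nM. This estimate means an expected step of a 1.4-fold lower number from compound 2 to compound 3 (0.13 log units; within the scatter).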

Compound 3, half-maximal inhibitory concentration: 5500 nM
Beside the measured number, compound 3's estimate is 5.5-fold (0.74 log units) above it; the measured number lies below the stated range.
By their numbers in this assay, from the lowest: compounds 3 and 1 (each within the scatter of the next); then compound 2.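

In this assay the group on the aromatic nitrogen proves able to move the number, with a 7.4-fold lower number from compound 2 to compound 3 (0.87 log units; beyond the scatter) once 4-chloro-3-(trifluoromethyl)phenyl, with 11 heavy atoms, replaces 4-bromophenyl, with 7. Among the compounds shown here, until now the only step on record was the fluoro change on the other side of the molecule, a 5.1-fold higher number from compound 1 to compound 2 (0.71 log units; beyond the scatter) so this is the first sign that the aryl group on the nitrogen also matters and that a step here can run toward stronger inhibition while the fluoro group stays in place. Nothing measured here explains why this swap lowers the number.

The swap changes two things at once, chlorine for bromine and an added trifluoromethyl group, so these compounds cannot show which of the two carries the step, or whether the same aryl group would give a similar step on the core without fluoro. Also open, as far as these compounds go, is how this position would respond to quite different groups, such as an aryl ring carrying an amine or a carboxylic acid, or a plain alkyl chain in place of the aryl ring.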